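Working notes: adding methylsulfanyl to compound 1

A few compounds are considered here, and "the series" means these few. Any claim that something is new, unique, unknown or untested is made for them only; others in the source may bear on it.

Compound 1 `CCOC(=O)c1cc(/C=C/c2ccccc2)on1` reads "not determined" (no result reported) (no result)
Compound 2 `CCOC(=O)c1cc(/C=C/c2ccc(C(F)(F)F)cc2)on1` reads "not determined" (no result reported) (no result)
Compound 3 `CCOC(=O)c1cc(/C=C/c2cccc(Cl)c2)on1` reads > 128000 nM (a limit)

In an ADME assay on Vero cells (Chlorocebus sabaeus) for cytotoxicity, with a stated time of 72 h (on this read-out lower numbers stand for stronger inhibition and higher numbers for weaker inhibition), compound 1 has no single number, so the step has no measured starting value. Compound 3 stands at a limit of the assay (> 128000 nM) and gives no exact number. Compound 4 `CCOC(=O)c1cc(/C=C/c2ccccc2SC)on1` is still to be measured. Its structure follows from methylsulfanyl in place of hydrogen on an aromatic carbon with methylsulfanyl in place of hydrogen on an aromatic carbon, ortho to a large group. For the measured compounds named here, no measured step is available to size this change, so in this assay the limit of compound 3 (> 128000 nM) serves as the only reference. Compound 4 is estimated at 128000 nM within an expected range of 50000 nM to 300000 nM in this read-out.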

Compound 4, half-maximal inhibitory concentration: > 128000 nM
Compound 4: only a limit was reported; the forecaster's own chance of this, stated with the estimate: 70%; the middle value sits exactly at the limit.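

No step can be read between compound 1 and compound 4 in this assay, as compound 1 has no single number there. Compound 4 gives > 128000 nM, which is a limit. The compounds shown leave open what size of change, if any, methylsulfanyl brings to this read-out.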